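Swapping the pendant aryl ring: from fluorophenyl to dichlorophenyl

This account rests on a few compounds, and the source may have more. Where it says the series, first, only, none or still open, it means among the compounds named here.

Measured compounds and their values:
compound 1 `COc1ccc(-c2cc(C)c(Nc3ccnc(Nc4ccc(C#N)cc4)n3)c(C)c2)cc1`: 2890 nM
compound 2 `COc1ccccc1-c1cc(C)c(Nc2ccnc(Nc3ccc(C#N)cc3)n2)c(C)c1`: 940 nM
compound 3 `Cc1cc(-c2cccc(F)c2)cc(C)c1Nc1ccnc(Nc2ccc(C#N)cc2)n1`: 4120 nM

All three share one core and differ only in the aryl ring attached to an aromatic carbon. In an ADME assay on MT4 cells (Homo sapiens) for cytotoxicity, read by MTT assay, with a stated time of 4 days (on this read-out higher numbers stand for lower toxicity in this test and lower numbers for higher toxicity in this test), compound 3 gives the highest of the three numbers. Its nearest neighbour is compound 1, with a 1.4-fold higher number from compound 1 to compound 3 (0.15 log units; within the scatter), so these two cannot be told apart. Its furthest neighbour is compound 2, with a 4.4-fold higher number from compound 2 to compound 3 (0.64 log units; beyond the scatter), a modest but real gap.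

Compound 4 `Cc1cc(-c2cc(Cl)cc(Cl)c2)cc(C)c1Nc1ccnc(Nc2ccc(C#N)cc2)n1` is the next variation. The change from compound 3 is 3,5-dichlorophenyl in place of 3-fluorophenyl on an aromatic carbon. All three measured steps concern this same ring position. Two of them, a 3.1-fold lower number from compound 1 to compound 2 (0.49 log units; beyond the scatter) and a 4.4-fold higher number from compound 2 to compound 3 (0.64 log units; beyond the scatter), were modest and real; the third, a 1.4-fold higher number from compound 1 to compound 3 (0.15 log units; within the scatter), lay within the scatter. Among the measured compounds shown here, no measured step involves two chlorines on this ring, so the direction cannot be read from the data. A change in this assay of at most modest size is expected, in either direction.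

Compound 4 is therefore expected to give about 3000 nM in this assay, between 1000 nM and 9000 nM, which corresponds to an expected step of a 1.4-fold lower number from compound 3 to compound 4 (0.14 log units; within the scatter).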

Compound 4, half-maximal cytotoxic concentration: 4290 nM
Compound 4: the middle estimate sits 1.4-fold (0.16 log units) below what was measured; measured number inside the range.
By their numbers in this assay, from the lowest: compound 2; then compounds 1, 3 and 4 (each within the scatter of the next).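

In this assay, 3,5-dichlorophenyl in place of 3-fluorophenyl gives a 1.0-fold higher number from compound 3 to compound 4 (0.02 log units; within the scatter) and so no change that can be told from the scatter: a ring with two chlorines on it cannot be separated from one with a single fluorine. Compared with the 4-methoxyphenyl ring there is a 1.5-fold higher number from compound 1 to compound 4 (0.17 log units; within the scatter) and again no readable difference, while compared with the 2-methoxyphenyl ring there is a 4.6-fold higher number from compound 2 to compound 4 (0.66 log units; beyond the scatter) as a modest but real gap, which leaves compound 2 as the one exception among these four aryl rings, with compounds 1, 3 and 4 forming a group that cannot be told apart. Nothing available explains why these rings give such similar numbers or why compound 2 stands apart.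

The compounds shown leave open whether the lower number of compound 2 belongs to the methoxy group itself or to where it sits on the ring. On these data alone, all four carry an aryl ring at this position, so it also stays open how the number would respond to an amine or a carboxylic acid on that ring, or to a saturated ring in its place.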